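The source may hold more compounds than are shown below. What is called first, only, known or untested is meant among the compounds shown, and "the series" means these compounds.

Measured compounds:
Compound 1, `COc1cccc(-c2nc(SCC(=O)c3sc(-c4ccccc4)nc3C)[nH]c(=O)c2C#N)c1`, giving 90.2%
Compound 2, `Cc1nc(-c2ccccc2)sc1C(=O)CSc1nc(-c2ccc(Cl)c(Cl)c2)c(C#N)c(=O)[nH]1`, giving 92.5%

Both compounds were tested in a functional assay on U-87MG ATCC cells for antiproliferative activity against U-87 MG (Homo sapiens), read by MTT assay, with a stated time of 48 h, tested at 10 uM; on this read-out higher numbers stand for a weaker effect at the one concentration tested and lower numbers for a stronger effect. Compound 2 stands together with compound 1 on this read-out: the step of a number 2.3 percentage points higher from compound 1 to compound 2 (within the scatter) lies within the scatter, so the two numbers cannot be told apart, and both point to a weak effect at the one concentration tested.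

Compound 3, `Cc1nc(-c2ccccc2)sc1C(=O)CSc1nc(-c2ccccc2)c(C#N)c(=O)[nH]1`, has not yet been measured. It differs from compound 2 by phenyl in place of 3,4-dichlorophenyl on an aromatic carbon. Among the measured compounds shown here, the only step available at the same place, the change of the aryl group between compound 1 and compound 2, stayed within the scatter. On that basis no step beyond the scatter is expected from compound 2 to compound 3 in this assay, and the step of a number 1.5 percentage points lower from compound 2 to compound 3 (within the scatter) is the estimate. Compound 3 is therefore expected to give about 91% in this assay, with a range from 80% to 100%.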

Compound 3, a percentage reported as activity, at one concentration (the size of the read-out at that concentration, not a potency): 87.5%
For compound 3 the middle estimate is 3.5 percentage points above the measured one; the range from low to high includes it.
By their numbers in this assay, from the lowest: compounds 3, 1 and 2 (each within the scatter of the next).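

Compound 3 adds what the earlier pair lacked: an aryl group with no substituent, here a phenyl on the aromatic carbon ortho to a cyano group, tested in this assay and read against both neighbours. Two steps now lead to it: a number 5 percentage points lower from compound 2 to compound 3 (within the scatter) for phenyl in place of 3,4-dichlorophenyl and a number 2.7 percentage points lower from compound 1 to compound 3 (within the scatter) for hydrogen in place of methoxy. On this read-out, neither the two chlorines nor the methoxy group can be told apart from the bare phenyl, and no measurement at hand speaks to the reason.

The compounds shown leave open whether an amine or a carboxylic acid on this phenyl, or a longer chain in its place, would give a step beyond the scatter. They also leave open whether a change elsewhere on the shared core would do so.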